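Imidazole Gives Way to Methylpiperazine on the Chain

The source may report more compounds than this note shows. Statements on the series, on what has been measured and on what is new or still open speak of the compounds shown alone.

Compound 1 `O=C1c2c[n+]([O-])c3ccccc3c2C(=O)c2c1c1ccccc1n2CCCCn1ccnc1` gives 240 nM in a functional assay on HCT-116 cells (Homo sapiens) for cytotoxicity, read by MTT assay, with a stated time of 72 h; on this read-out higher numbers stand for weaker inhibition and lower numbers for stronger inhibition. Compound 2 `CC1(C)OC[C@@H](Cn2cc(Cn3c4c(c5ccccc53)C(=O)c3c[n+]([O-])c5ccccc5c3C4=O)nn2)O1` gives 340 nM in this assay; the two values lie within the scatter of each other, so compound 1 holds the lowest of the two numbers without standing apart from compound 2. Compound 3 `CN1CCN(CCCn2c3c(c4ccccc42)C(=O)c2c[n+]([O-])c4ccccc4c2C3=O)CC1` differs from compound 1 in one place: 4-methylpiperazin-1-yl in place of (1H-imidazol-1-yl)methyl on a saturated chain carbon, three bonds along the chain from an aromatic nitrogen. Among the measured compounds shown here, no step between measured compounds shows how such a change reads out, so nothing in the data points either way. For compound 3 the expected step is a 1.1-fold higher number from compound 1 to compound 3 (0.03 log units; within the scatter), which should stay inside the scatter. Compound 3 is estimated at 260 nM, between 110 nM and 620 nM.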

Compound 3, half-maximal inhibitory concentration: 560 nM
For compound 3 the middle estimate is 2.2-fold (0.33 log units) below the measured one, and the stated range covers the measured number.
By their numbers in this assay, from the lowest: compounds 1, 2 and 3 (each within the scatter of the next, the first and the last beyond it).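

Among the compounds shown here, replacing (1H-imidazol-1-yl)methyl with 4-methylpiperazin-1-yl on a saturated chain carbon, three bonds along the chain from an aromatic nitrogen, gives a 2.3-fold higher number from compound 1 to compound 3 (0.37 log units; beyond the scatter) in this assay and so provides the first reading at this position: the number responds to this change, though only modestly. Nothing available explains the step. The compounds shown leave open whether the step follows the ring or the chain length, as the change also alters the butyl chain to a propyl chain. A 3-(1H-imidazol-1-yl)propyl chain or a 4-(4-methylpiperazin-1-yl)butyl chain could separate the two, and a morpholine on the same chain would test another ring.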